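Bis-indole pyridine series: nitrile removal checked at one concentration

The compounds below may be only part of what the source reports. "The series", "measured", "known", "first", "only" and "open" are said of these compounds alone.

Measured so far:
compound 1 `COc1ccc2c(c1)c(-c1cc(C(F)(F)F)c(C#N)c(-c3cn(S(=O)(=O)c4ccc(C)cc4)c4ccc(OC)cc34)n1)cn2S(=O)(=O)c1ccc(C)cc1` — 25%
compound 2 `COc1ccc2c(c1)c(-c1cc(C(F)(F)F)ccn1)cn2S(=O)(=O)c1ccc(C)cc1` — 16.9%

Both numbers come from a functional assay on A549 cells (Homo sapiens) for inhibition, tested at 0.1 uM; a lower number here means a weaker effect, a higher number a stronger effect of the compound at the concentration tested. Compound 1 gives 25% in this assay, the higher of the two numbers, while compound 2 gives 16.9%. The gap between the two is within the scatter, so the two compounds cannot be placed in an order on this assay. Among the compounds with values here, no step between two compounds differing in one place is on record, so nothing is yet known about how a single change moves the read-out.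

Compound 3 `COc1ccc2c(c1)c(-c1cc(C(F)(F)F)cc(-c3cn(S(=O)(=O)c4ccc(C)cc4)c4ccc(OC)cc34)n1)cn2S(=O)(=O)c1ccc(C)cc1` is not yet measured. It differs from compound 1 in one place: hydrogen in place of cyano on an aromatic carbon.

Within the data shown here, with no step of this kind available, and with the two measured numbers sitting within the scatter of each other, the read-out of compound 3 is expected to stay in the same low region and the step of a number 5 percentage points lower from compound 1 to compound 3 (within the scatter) is expected to be none beyond the scatter. Compound 3 is estimated at 20% in this assay, within a range of 5% to 35%.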

Compound 3, a percentage reported as inhibition, at one concentration (the size of the read-out at that concentration, not a potency): 16.7%
For compound 3 the middle estimate is 3.3 percentage points above the measured one; measured number inside the range.
By their numbers in this assay, from the lowest: compounds 3, 2 and 1 (each within the scatter of the next).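

Working notes on the nitrile position: compound 1 and compound 3 give the only single-place step on record in the series. In this assay, hydrogen in place of cyano on the aromatic carbon ortho to a trifluoromethyl group and two atoms from the ring nitrogen gives a number 8.3 percentage points lower from compound 1 to compound 3 (within the scatter), so at this position the cyano group is not shown to be needed for the read-out at the tested concentration. No measured property bears on this result, so the step can be recorded but not interpreted.

On these data alone, it remains open whether any group on this carbon can move the read-out beyond the scatter, and an amine, a carboxylic acid or a primary amide there would test this against the hydrogen of compound 3 and the cyano of compound 1. A single-concentration read-out in this low region also leaves open whether the two compounds would still be indistinguishable in a full concentration-response comparison.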